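This account rests on a few compounds, and the source may have more. Where it says the series, first, only, none or still open, it means among the compounds named here.

Of the compounds shown here, two have so far been tested in a functional assay on MCF7 cells (Homo sapiens) for antiproliferative activity, read by MTT assay, with a stated time of 24 h; on this read-out lower numbers stand for stronger inhibition and higher numbers for weaker inhibition. Compound 1 `Clc1ccc(C2CC(c3ccccc3)=NN2c2ccc(-c3ccccc3)nn2)cc1` gives 100000 nM in this assay. Compound 2 `COc1ccc(C2=NN(c3ccc(-c4ccccc4)nn3)C(c3ccc(Cl)cc3)C2)cc1` differs from it by a methoxy in place of hydrogen on an aromatic carbon, and in this assay compound 2 gives 58000 nM. The step of a 1.7-fold lower number from compound 1 to compound 2 (0.24 log units; within the scatter) shows that these two numbers lie within the scatter of each other, so compound 2 stands level with compound 1 rather than apart from it; no ordering between the two can be drawn from these figures.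

Compound 3 `COc1ccc(C2=NN(c3ccc(-c4ccccc4)nn3)C(c3ccc(OC)cc3)C2)cc1` has not yet been measured. It differs from compound 2 by methoxy in place of chloro on an aromatic carbon. Among the compounds with values here, the only measured step that bears on this change is a 1.7-fold lower number from compound 1 to compound 2 (0.24 log units; within the scatter), which introduced a methoxy on a different aromatic carbon and stayed within the scatter. Within the data shown here, nothing measured so far speaks for a shift beyond the scatter, so the expected step of a 1.0-fold higher number from compound 2 to compound 3 (0.01 log units; within the scatter) is small. Compound 3 is therefore estimated at 60000 nM in this assay, with a range from 25000 nM to 150000 nM.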

Compound 3, half-maximal inhibitory concentration: 100000 nM
For compound 3 the middle estimate is 1.7-fold (0.22 log units) below the measured one; the range from low to high includes it.
By their numbers in this assay, from the lowest: compounds 2, 1 and 3 (each within the scatter of the next).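

Within the data shown here, compound 3 gives the first reading at this position: replacing the 4-chlorophenyl group with 4-methoxyphenyl yields a 1.7-fold higher number from compound 2 to compound 3 (0.24 log units; within the scatter) in this assay, so this read-out does not separate chloro from methoxy at this carbon, para to a large group. The earlier step, a 1.7-fold lower number from compound 1 to compound 2 (0.24 log units; within the scatter), placed a methoxy on a different aromatic carbon, so it could not show how the group behaves here; the new step also shows that a hydrogen-bond acceptor, which methoxy counts as and chloro does not, can enter at this place with the number staying within the scatter. Nothing available bears on why the two groups read alike here.

The compounds shown carry only chloro and methoxy at this carbon, so it remains open whether an amine, a carboxylic acid or a longer chain such as butoxy would shift the number beyond the scatter. From the compounds shown here alone, all three compounds lie within the scatter of each other, and it also remains open whether chloro and methoxy would still read alike on a core that gives a much lower number in this assay.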